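Swapping the carboxyphenyl ring on the tether of compound 3

A few compounds are considered here, and "the series" means these few. Any claim that something is new, unique, unknown or untested is made for them only; others in the source may bear on it.

Measured compounds:
Compound 1, `Cc1c(OCCCCOc2ccccc2C(=O)O)ccc(C(=O)CC2CCCC2)c1C`: 67.1%
Compound 2, `Cc1c(OCCCCOc2ccc(F)c(C(=O)O)c2)ccc(C(=O)CC2CCCC2)c1O`: 81%
Compound 3, `Cc1c(OCCCCOc2ccc(C(=O)O)c(Cl)c2)ccc(C(=O)CC2CCCC2)c1C`: 61.8%

Three compounds share a ketone-bearing core joined through a four-carbon chain to a carboxyphenyl ring. In an assay on HEK293 cells for positive allosteric modulation of metabotropic glutamate receptor 2 (Rattus norvegicus), read by thallium flux, with a stated time of 2.5 min (on this read-out lower numbers stand for smaller maximal responses and higher numbers for larger maximal responses), compound 3 gives 61.8%, the smallest of the three numbers shown; compound 1 sits within the scatter of it, compound 2 beyond it.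

The next compound, compound 4 `Cc1c(OCCCCOc2ccc(F)c(C(=O)O)c2)ccc(C(=O)CC2CCCC2)c1C`, keeps the core of compound 3 and changes only the ring at the end of the chain: 3-carboxy-4-fluorophenyl in place of 4-carboxy-3-chlorophenyl on an oxygen on a saturated carbon.

Among the measured compounds shown here, one measured step touches the same position. It gave a number 5.3 percentage points lower from compound 1 to compound 3 (within the scatter), so exchanging one carboxyphenyl ring for another there did not move the read-out beyond the scatter. Compound 2 carries the ring that enters in compound 4, but on a different core, so its value can only be read alongside those of compound 1 and compound 3. For compound 4 the expected step is therefore small, a number 6.2 percentage points higher from compound 3 to compound 4 (within the scatter). Compound 4 is estimated at 68%, within 55% to 82%.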

Compound 4, largest response reached (reported as percent of maximum), in percent of the reference or control that the assay uses: 14.6%
Estimate against measurement, compound 4: 53.4 percentage points above, outside the stated range (below it).
By their numbers in this assay, from the lowest: compound 4; then compounds 3 and 1 (each within the scatter of the next); then compound 2.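

In this assay the ring at the end of the chain proved far from interchangeable on this core: 3-carboxy-4-fluorophenyl in place of 4-carboxy-3-chlorophenyl gave a number 47.2 percentage points lower from compound 3 to compound 4 (beyond the scatter) and in place of 2-carboxyphenyl gave a number 52.5 percentage points lower from compound 1 to compound 4 (beyond the scatter) while the earlier exchange at this place stayed within the scatter. The low number does not follow from that ring alone, since compound 2 carries the same ring and methyl in place of hydroxy on an aromatic carbon gave a number 66.4 percentage points lower from compound 2 to compound 4 (beyond the scatter) so among these compounds the ring and that group act together. Nothing shown explains these steps.

Open, as far as these compounds go, is whether the fall goes with the fluorine or with where the carboxy group sits, which a 3-carboxyphenyl ring on the core of compound 4 would separate. Also open, from the compounds shown here alone, is how the other two rings behave on the core of compound 2.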